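This account rests on a few compounds, and the source may have more. Where it says the series, first, only, none or still open, it means among the compounds named here.

For the measured compounds named here, in a functional assay on P388 cells (Mus musculus) for cytotoxicity (a lower number here means a stronger inhibitor, a higher number a weaker inhibitor), compound 2 `Cc1cc(-c2c(F)cc3c(=O)c(Cc4ccccc4)cn(C4CC4)c3c2F)cc(C)n1` gives 7300 nM, the lower of the two numbers measured so far, while compound 1 `COc1ccc(Cc2cn(C3CC3)c3c(F)c(-c4cc(C)nc(C)c4)c(F)cc3c2=O)cc1` gives 21000 nM. Compound 3 `Cc1cc(-c2c(F)cc3c(=O)c(Cc4cccc(O)c4O)cn(C4CC4)c3c2F)cc(C)n1` keeps the shared core of compound 2 and changes only the benzyl group, which becomes 2,3-dihydroxybenzyl: 2,3-dihydroxyphenyl in place of phenyl on a saturated chain carbon bound to an aromatic carbon. Going by the values given here, one measured step bears on this change, hydrogen in place of methoxy on an aromatic carbon, and it is a 2.9-fold lower number from compound 1 to compound 2 (0.46 log units; beyond the scatter). That step is modest, and it suggests that a change on this ring can shift the number by a similar size. Its direction carries over poorly, since hydroxy is not methoxy, so only a modest move toward a lower number is tentatively expected in this assay. The expected change is a 2.4-fold lower number from compound 2 to compound 3 (0.39 log units; beyond the scatter). For compound 3 the estimated value is 3000 nM, with an expected range from 500 nM to 15000 nM.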

Compound 3, half-maximal inhibitory concentration: 880 nM
Compound 3: the middle estimate sits 3.4-fold (0.53 log units) above what was measured, within the range that was stated.
By their numbers in this assay, from the lowest: compound 3; then compound 2; then compound 1.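

In this assay, for the compounds shown here, the earlier compounds showed only that a methoxy group on this ring goes with a higher number than plain phenyl, whereas 2,3-dihydroxyphenyl in place of phenyl gives an 8.3-fold lower number from compound 2 to compound 3 (0.92 log units; beyond the scatter) and so shows that a substituted ring on this saturated chain carbon can also lower the number. Set against the 4-methoxyphenyl compound, the change gives a 24-fold lower number from compound 1 to compound 3 (1.38 log units; beyond the scatter) and shows that the outcome depends on which groups the ring carries, not merely on whether it carries any. Nothing measured here explains why the two hydroxy groups go with this drop.

The compounds shown leave open whether both hydroxy groups are needed or whether 3-hydroxyphenyl alone would do the same. They also leave open whether 2,3-dimethoxyphenyl or 2,3-diaminophenyl would follow the same direction.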